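A few compounds are considered here, and "the series" means these few. Any claim that something is new, unique, unknown or untested is made for them only; others in the source may bear on it.

Measured compounds:
Compound 1, `CCc1ccc(-c2cc(C(=O)Nc3ccc(Oc4ccnc(C(=O)NC)c4)cc3)ncn2)cc1`: 29300 nM
Compound 2, `CCc1ccc(-c2cc(C(=O)Nc3ccc(Oc4ccnc(C(=O)NC)c4)c(F)c3)ncn2)cc1`: 15600 nM
Compound 3, `CNC(=O)c1cc(Oc2ccc(NC(=O)c3cc(-c4ccc(OC)cc4)ncn3)cc2F)ccn1`: 56200 nM

All three were run in a functional assay on PC-3 cells (Homo sapiens) for cytotoxicity, read by MTT assay, with a stated time of 72 h; on this read-out lower numbers stand for stronger inhibition and higher numbers for weaker inhibition. Compound 1 gives 29300 nM in this assay, compound 2 gives 15600 nM, and compound 3 gives 56200 nM, the highest of the three numbers.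

Compound 4, `CNC(=O)c1cc(Oc2ccc(NC(=O)c3cc(-c4ccc(OC)cc4)ncn3)cc2)ccn1`, has not been measured in this assay. It relates to compound 3 as compound 1 relates to compound 2: the change is hydrogen in place of fluoro on an aromatic carbon. The measured instance of the same change is hydrogen in place of fluoro on an aromatic carbon, and that step came out as a 1.9-fold higher number from compound 2 to compound 1 (0.27 log units; within the scatter), a shift that stays within the scatter of repeated measurements. The two places are described in identical words, so the change is regarded as the same one.

The cores of compound 2 and compound 3 differ by methoxy in place of ethyl on an aromatic carbon, and that step measured as a 3.6-fold higher number from compound 2 to compound 3 (0.56 log units; beyond the scatter). Compound 4 therefore starts from the weaker of the two cores.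

Within the data shown here, with only one measured instance of the change, the expectation for compound 4 rests on the step from compound 2 to compound 1 alone. The step from compound 3 to compound 4 is expected to be about a 1.8-fold higher number from compound 3 to compound 4 (0.25 log units; within the scatter), because the earlier step of a 1.9-fold higher number from compound 2 to compound 1 (0.27 log units; within the scatter) was of that order and within the scatter. Compound 4 is estimated at 100000 nM in this assay, with a range from 45000 nM to 220000 nM. Given how high the number for compound 3 already stands, a reading reported only as a limit is a real possibility.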

Compound 4, half-maximal inhibitory concentration: 38800 nM
Estimate against measurement, compound 4: 2.6-fold (0.41 log units) above, and the stated range ends above it.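

In this assay, hydrogen in place of fluoro gives a 1.4-fold lower number from compound 3 to compound 4 (0.16 log units; within the scatter), so this change does not carry over as a fixed step from one core to the other: the same change on two cores in this assay, a 1.9-fold higher number (0.27 log units; within the scatter) from compound 2 to compound 1 and a 1.4-fold lower number (0.16 log units; within the scatter) from compound 3 to compound 4, 2.7-fold (0.43 log units) apart, beyond the scatter of two such steps

Methoxy in place of ethyl gives a 1.3-fold higher number from compound 1 to compound 4 (0.12 log units; within the scatter) on the core without fluoro, so this change also does not carry over as a fixed step: the same change on two cores in this assay, a 3.6-fold higher number (0.56 log units; beyond the scatter) from compound 2 to compound 3 and a 1.3-fold higher number (0.12 log units; within the scatter) from compound 1 to compound 4, 2.7-fold (0.43 log units) apart, beyond the scatter of two such steps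

Compounds 1, 2, 3 and 4 form a single square of changes, so the two gaps rest on the same four values and amount to one finding rather than two independent ones; they show that, among these compounds, the size of each step depends on the other position, but they do not show why, and they give no rule for other cores.

As far as these compounds go, it remains open whether chloro or a methyl group in place of the fluoro would behave like hydrogen, and whether the same dependence would hold on cores carrying a longer chain or an amine in place of ethyl or methoxy. Also open, from the compounds shown here alone, is whether the dependence seen here would recur in a second cell line or a target-level read-out, which the four values in this single cell assay cannot settle.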